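The source may report more compounds than this note shows. Statements on the series, on what has been measured and on what is new or still open speak of the compounds shown alone.

Measured compounds:
- compound 1 `CCC/C=C/C(=O)N(Cc1ccc(OC)c(O)c1)c1cc(OC)c(OC)c(OC)c1` gives 95 nM in a functional assay on HCT-116 cells (Homo sapiens) for inhibition, read by MTT assay, with a stated time of 48 h; on this read-out higher numbers stand for weaker inhibition and lower numbers for stronger inhibition
- compound 2 `COc1ccc(N(Cc2cc(OC)c(OC)c(OC)c2)C(=O)CCl)cc1O` gives 22500 nM in this assay
- compound 3 `COc1ccc(CNc2cc(OC)c(OC)c(OC)c2)cc1N` gives 8270 nM in this assay

Of these three, compound 1 has the lowest number, and so the strongest inhibition; the gap to compound 3 and the larger gap to compound 2 both lie beyond the usual scatter, so compound 1 stands clearly apart as the most potent of the measured set.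

Compound 4 `COc1ccc(CN(C(=O)CO)c2cc(OC)c(OC)c(OC)c2)cc1O` has not yet been measured. It differs from compound 1 in one place: hydroxymethyl in place of pent-1-en-1-yl on a carbonyl carbon. Among the measured compounds shown here, no directly comparable step between measured compounds exists, so the size of the change can only be judged from the set as a whole. In that set, compound 2, whose amide carries a chloromethyl group rather than a longer chain, gives 22500 nM, far weaker than compound 1. On that basis a large loss of inhibition is expected for compound 4, giving a step of a 63-fold higher number from compound 1 to compound 4 (1.80 log units; beyond the scatter) towards a higher number. The estimate for compound 4 is 6000 nM, with a range from 1000 nM to 35000 nM.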

Compound 4, half-maximal inhibitory concentration: 520 nM
Beside the measured number, compound 4's estimate is 12-fold (1.06 log units) above it, outside the stated range (below it).
By their numbers in this assay, from the lowest: compound 1; then compound 4; then compound 3; then compound 2.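

In this assay, placing hydroxymethyl instead of pent-1-en-1-yl on the carbonyl carbon gives a 5.5-fold higher number from compound 1 to compound 4 (0.74 log units; beyond the scatter) and so counts as a modest change. This position therefore accepts a very different group, an oxygen-bearing hydroxymethyl in place of an all-carbon chain with a double bond, at only a limited cost in inhibition. The pent-1-en-1-yl group adds to the inhibition, but compound 4 shows that the chain is not essential for it.

Going by these compounds, it remains open whether the lost chain length or the added oxygen sets the size of this step, a question that groups such as ethyl, methoxymethyl or aminomethyl on the same carbonyl carbon could help to separate. Nothing presented here accounts for the size of the step.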